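Amine-linked phenols: chain extension and tolerated concentration

The source may hold more compounds than are shown below. What is called first, only, known or untested is meant among the compounds shown, and "the series" means these compounds.

Measured so far:
compound 1, `CCCCNCc1ccc(O)cc1`, > 300000 nM
compound 2, `CCCCCCCC(=O)/C=C/c1ccc(O)cc1`, 82800 nM

In an ADME assay on NCTC-929 cells (Mus musculus, culture collection number NCTC 929) for cytotoxicity, read by MTT assay, with a stated time of 48 h (a lower number here means that less compound is tolerated, a higher number that more compound is tolerated), compound 1 gives > 300000 nM. This is a limit of the assay and not a number (the limit of > 300000 nM in this assay, at which 1 of the 2 values shown sits). Compound 2 is measured with a number in this assay, where compound 2 gives 82800 nM. Going by the values given here, compound 1 and compound 2 share the phenol ring but differ at the linker; no single-change step between them is computed, so the two values are set side by side only: compound 2 is tolerated up to a measured concentration, compound 1 is tolerated beyond what the assay resolves.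

Compound 3, `CCCCCCCCNCc1ccc(O)cc1`, has not yet been measured. It differs from compound 1 by butyl in place of hydrogen on a saturated chain carbon, four bonds along the chain from an amine nitrogen. Among the compounds with values here, because compound 1 stands at the limit (the limit of > 300000 nM in this assay, at which 1 of the 2 values shown sits), no measured pair gives the size of such a step. The step is nevertheless expected to go downward, beyond the scatter, with less compound tolerated: an at least 3.0-fold lower number from compound 1 to compound 3 (0.47 log units; beyond the scatter). Compound 3 is expected to give about 100000 nM, within 30000 nM to 300000 nM.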

Compound 3, half-maximal cytotoxic concentration: 23500 nM
Beside the measured number, compound 3's estimate is 4.3-fold (0.63 log units) above it; measured number below the stated range.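

Going by these compounds alone, at this position, four bonds along the chain from an amine nitrogen, butyl in place of hydrogen gives an at least 12-fold lower number from compound 1 to compound 3 (1.10 log units; beyond the scatter) in this assay, the first single-change step and one that lies beyond the scatter. With compound 3 at 23500 nM, the amine-linked series now has a measured number, and the chain on the amine nitrogen is shown to be a place where a single change moves the tolerated concentration. Compound 1 stands at a limit of the assay and not at a number, which makes the printed size of the step a minimum and not an exact figure: the limit of > 300000 nM in this assay, at which 1 of the 3 values shown sits.

Going by these compounds, whether a longer chain at this position lowers the number further, and whether a branched chain or a chain ending in a carboxylic acid behaves like the butyl extension, remains open. With a single step at a single position, the change per added carbon cannot be read, and nothing yet shows whether the step holds on a core with a different linker.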